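A few compounds are considered here, and "the series" means these few. Any claim that something is new, unique, unknown or untested is made for them only; others in the source may bear on it.

Measured compounds:

Compound 1, `Cc1ccc(C2=NN(c3ccc(S(N)(=O)=O)cc3)C(c3cn(-c4ccccc4)nc3-c3ccc(F)cc3)C2)cc1`: in an ADME assay on Vero cells (Chlorocebus sabaeus) for cytotoxicity, read by MTT assay, with a stated time of 72 h (a higher number here means that more compound is tolerated, a lower number that less compound is tolerated), compound 1 gives > 90600 nM, a limit of the assay.
Compound 2, `Cc1ccc(C2=NN(c3ccc(S(N)(=O)=O)cc3)C(c3cn(-c4ccccc4)nc3-c3ccc(C)cc3)C2)cc1`: in this assay compound 2 gives > 41400 nM, again a limit.

Among the compounds with values here, compound 2 therefore stands at a limit, not at a number; the one other value is likewise a limit. The measured step, a step that the two limits leave unreadable from compound 1 to compound 2, is unreadable because one value sits at the limit of > 41400 nM in this assay, at which 1 of the 2 values shown sits, and the other at the limit of > 90600 nM in this assay, at which 1 of the 2 values shown sits, so no size can be drawn from it.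

Compound 3, `Cc1ccc(-c2nn(-c3ccccc3)cc2C2CC(c3ccccc3)=NN2c2ccc(S(N)(=O)=O)cc2)cc1`, differs from compound 2 by hydrogen in place of methyl on an aromatic carbon. Within the data shown here, no measured step bears directly on this change; the only recorded step is the unreadable one from compound 1 to compound 2. Both measured members of the series are tolerated up to their limits, so for compound 3 the expectation is no change beyond the scatter: the step that the limit leaves unreadable from compound 2 to compound 3 is estimated to be flat, with a strong chance that this assay again reports only a limit. Compound 3 is expected at 80000 nM, in the range 30000 nM to 300000 nM.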

Compound 3, half-maximal cytotoxic concentration: > 161000 nM
Compound 3 ended at the assay's limit; the forecaster's own chance of this, stated with the estimate: 80%; middle value at least 2.0-fold (0.30 log units) from the limit.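

In this assay compound 3 gives > 161000 nM, again a limit and not a number. Compound 2 also stands at a limit, and the step between compound 2 and compound 3 cannot be read. The compounds shown leave open where the actual cytotoxic concentrations lie, and whether either single change, methyl for fluoro or hydrogen for methyl, alters tolerance at all.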